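The source may report more compounds than this note shows. Statements on the series, on what has been measured and on what is new or still open speak of the compounds shown alone.

Compound 1 `O=C(O)[C@@H](CC1CCC1)N1C[C@H](CN2CCC(c3cnc4ccc([N+](=O)[O-])cn34)CC2)[C@@H](c2cccc(F)c2)C1` is the better of the two compounds measured in an in vivo ADME assay on the whole organism (Rattus norvegicus) for pharmacokinetics; on this read-out lower numbers stand for lower oral bioavailability and higher numbers for higher oral bioavailability: compound 1 reaches 61%, while compound 2 `O=C(O)[C@@H](CC1CCC1)N1C[C@H](CN2CCC(CCCc3ccccc3)CC2)[C@@H](c2ccccc2)C1` gives 29%, a gap beyond the usual scatter. Compound 3 `O=C(O)[C@@H](CC1CCC1)N1C[C@H](CN2CCC(c3cnc4ccc(Cl)cn34)CC2)[C@@H](c2cccc(F)c2)C1` has not yet been measured in this assay. Compound 3 differs from compound 1 in one place: chloro in place of nitro on an aromatic carbon. Going by the values given here, no step between measured compounds shows what this change does, so the expectation for compound 3 rests on compound 1 alone and on the change itself. The step of a number 6 percentage points lower from compound 1 to compound 3 (within the scatter) is expected to be small, with neither direction clearly favoured. Compound 3 is thus estimated at 55%, within a range from 35% to 75%.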

Compound 3, oral bioavailability: 26%
Beside the measured number, compound 3's estimate is 29 percentage points above it; measured number below the stated range.
By their numbers in this assay, from the lowest: compounds 3 and 2 (each within the scatter of the next); then compound 1.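

At this aromatic carbon, the group carried there matters greatly in this assay: chloro in place of nitro gives a number 35 percentage points lower from compound 1 to compound 3 (beyond the scatter), although the rest of the molecule stays the same. Going by these compounds alone, no earlier pair of compounds isolated this position, so this is the first sign that one small substituent here can strongly change oral bioavailability. Nothing measured here explains the drop. From the compounds shown here alone, it remains open whether nitro is unusually favourable here or chloro unusually unfavourable; a nitrile or an amine on the same carbon would help separate these possibilities. Going by these compounds, whether the same step would hold with a different group elsewhere on the core also remains open.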